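This account rests on a few compounds, and the source may have more. Where it says the series, first, only, none or still open, it means among the compounds named here.

In a functional assay on PC-3 cells (Homo sapiens) for cytotoxicity, read by sulforhodamine B assay, with a stated time of 48 h (a higher number here means a weaker inhibitor, a lower number a stronger inhibitor), compound 1 (`COc1cc(C2=NO[C@]3(C2)C(=O)O[C@@H]2[C@H]3CC[C@H](C)[C@]3(O)C=CC(=O)[C@@]23C)ccc1O`) stands at 16000 nM and compound 2 (`C[C@H]1CC[C@@H]2[C@@H](OC(=O)[C@]23CC(c2cccc([N+](=O)[O-])c2)=NO3)[C@]2(C)C(=O)C=C[C@@]12O`) at 55000 nM as the higher of the two numbers. For the measured compounds named here, the one measured step is a 3.4-fold higher number from compound 1 to compound 2 (0.54 log units; beyond the scatter) as a modest change beyond the scatter, with 3-nitrophenyl in place of 4-hydroxy-3-methoxyphenyl on a carbon with a double bond to nitrogen. Compound 3 (`C[C@H]1CC[C@@H]2[C@@H](OC(=O)[C@]23CC(c2ccccc2Cl)=NO3)[C@]2(C)C(=O)C=C[C@@]12O`) changes that same carbon again, with 2-chlorophenyl in place of 3-nitrophenyl (2-chlorophenyl in place of 3-nitrophenyl on a carbon with a double bond to nitrogen). Going by the values given here, no measured compound carries chlorine, so this single step is only a rough guide to size. It points to a small or modest move in this assay toward a lower number, with compound 2 at 55000 nM as the top of the range so far. The expected change is a 2.0-fold lower number from compound 2 to compound 3 (0.29 log units; within the scatter) as an estimate. Compound 3 is estimated at 28000 nM within an expected range of 10000 nM to 70000 nM for now.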

Compound 3, half-maximal inhibitory concentration: 12000 nM
Compound 3: middle estimate off by 2.3-fold (0.37 log units), on the high side; low and high end bracket the measured number.
By their numbers in this assay, from the lowest: compounds 3 and 1 (each within the scatter of the next); then compound 2.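

At the carbon with a double bond to nitrogen, the aryl group can shift the read-out in this assay in either direction: 2-chlorophenyl in place of 3-nitrophenyl gives a 4.6-fold lower number from compound 2 to compound 3 (0.66 log units; beyond the scatter) and leaves compound 2 apart from the other two compounds. 2-Chlorophenyl in place of 4-hydroxy-3-methoxyphenyl gives a 1.3-fold lower number from compound 1 to compound 3 (0.12 log units; within the scatter) and so shows that neither the hydroxy nor the methoxy group is required for the level of compound 1 in this series. No data bearing on the reason for these differences are available.

As far as these compounds go, whether the gap comes from the nitro group or from its place on the ring stays open, since 2-chlorophenyl changes both at once. Also open, from the compounds shown here alone, is how an unsubstituted phenyl, 3-chlorophenyl, or an aryl group carrying an amine or a carboxylic acid would read at this carbon.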